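A Methyl Added to the Phenoxy Group of Compound 2

The source may report more compounds than this note shows. Statements on the series, on what has been measured and on what is new or still open speak of the compounds shown alone.

Two compounds of this set have measured values. Compound 1, `COC(=O)c1sc(Oc2cccc(C)c2)c(C#N)c1N`, carries a methyl ester on the shared core and a 3-methylphenoxy group; in a physicochemical assay for lipophilicity (on this read-out lower numbers stand for lower lipophilicity and higher numbers for higher lipophilicity), compound 1 gives 4.16. Compound 2, `N#Cc1c(Oc2ccccc2)sc(C(=O)c2ccc([N+](=O)[O-])cc2)c1N`, carries a ketone-linked nitro-bearing ring on the same core together with a plain phenoxy group; in this assay compound 2 gives 4.53. Of the two numbers, compound 2 stands highest, and its nearest neighbour is compound 1, which lies lower by a gap beyond the usual scatter.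

Compound 3, `Cc1cccc(Oc2sc(C(=O)c3ccc([N+](=O)[O-])cc3)c(N)c2C#N)c1`, has not yet been measured. It differs from compound 2 by a single change: methyl in place of hydrogen on an aromatic carbon. Among the compounds with values here, no pair of measured compounds shows this change in isolation, so its size cannot be read from the data. Adding one carbon without any donor or acceptor is expected to raise this read-out by a step larger than the scatter, from compound 2 to compound 3 estimated as a number 0.47 log units higher from compound 2 to compound 3 (beyond the scatter). For compound 3 the expected value in this assay is 5, with a range from 4.7 to 5.4.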

Compound 3, partition coefficient: 5.03
Beside the measured number, compound 3's estimate is 0.03 log units below it; the measured number falls inside the stated range.
By their numbers in this assay, from the lowest: compound 1; then compound 2; then compound 3.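

In this assay, methyl in place of hydrogen on an aromatic carbon of the phenoxy group now has a measured size, a number 0.50 log units higher from compound 2 to compound 3 (beyond the scatter), so this single change at this place moves the read-out by more than the usual scatter. Compound 3 also isolates a second change that compounds 1 and 2 could not separate, as they differ in two places: with the 3-methylphenoxy group held constant, 4-nitrophenyl in place of methoxy on a carbonyl carbon gives a number 0.87 log units higher from compound 1 to compound 3 (beyond the scatter). Nothing measured here goes beyond these numbers to account for the size of either step.

The methyl step has been read only once, on the core bearing the ketone-linked nitro-bearing ring, so the compounds shown leave open whether it would be the same size with the methyl ester in that place or with the methyl elsewhere on the ring. They also leave open how the read-out would respond to an ethyl group, an amine or a carboxylic acid at the position that carries the methyl in compound 3.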